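Benzylamino in Place of Methyl on the Carbonyl

The source may report more compounds than this note shows. Statements on the series, on what has been measured and on what is new or still open speak of the compounds shown alone.

Compound 1 `O/N=C(/Nc1ccccc1)c1ccc2occc2c1`: 19000 nM
Compound 2 `CC(=O)c1cccc(N/C(=N/O)c2ccc3occc3c2)c1`: > 30000 nM

In an assay on tissue (HeLa cells) for inhibition of Indoleamine 2,3-dioxygenase 1 (Homo sapiens), read by spectrophotometry (a higher number here means a weaker inhibitor, a lower number a stronger inhibitor), compound 1 gives 19000 nM. Compound 2 reaches only a limit of the assay, > 30000 nM. Compound 2 thus stands at the limit of > 30000 nM in this assay, at which 1 of the 2 values shown sits. Among the measured compounds shown here, the one measured step, an at least 1.5-fold higher number from compound 1 to compound 2 (0.19 log units; that floor lies within the scatter), came with acetyl in place of hydrogen on an aromatic carbon. Compound 3 `O=C(NCc1ccccc1)c1cccc(N/C(=N/O)c2ccc3occc3c2)c1` differs from compound 2 by benzylamino in place of methyl on a carbonyl carbon. For the measured compounds named here, no measured step alters the group on this carbonyl carbon, so the expectation rests on compound 2 being a weak inhibitor at its limit and amounts to no step beyond the scatter, a number no higher from compound 2 to compound 3 (the limit leaves the size open). Compound 3 is therefore estimated at 30000 nM, within 8000 nM to 100000 nM.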

Compound 3, half-maximal inhibitory concentration: > 30000 nM
Compound 3 gave a limit, no number; the forecaster's own chance of this, stated with the estimate: 55%; the middle value lies on the limit itself.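

Among the compounds shown here, no step from compound 2 to compound 3 can be read, since both stand at a limit rather than at a number: the limit of > 30000 nM in this assay, at which 2 of the 3 values shown sit. As far as these compounds go, how far benzylamino in place of methyl on the carbonyl carbon shifts the result in this assay stays open, in either direction.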